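A few compounds are considered here, and "the series" means these few. Any claim that something is new, unique, unknown or untested is made for them only; others in the source may bear on it.

Compound 1 `O=Cc1ccccc1OCc1cn(CCCOc2ccc3ccc(=O)oc3c2)nn1` is, in a functional assay on HT-29 cells (Homo sapiens) for cytotoxicity, read by MTT assay, with a stated time of 24 h (on this read-out higher numbers stand for weaker inhibition and lower numbers for stronger inhibition), the weaker of the two measured compounds: compound 1 gives 18900 nM, whereas compound 2 `CCN(CC)c1ccc(C=O)c(OCc2cn(CCCOc3ccc4ccc(=O)oc4c3)nn2)c1` gives 9030 nM, and the step of a 2.1-fold lower number from compound 1 to compound 2 (0.32 log units; beyond the scatter) lies beyond the scatter. Compound 3 `COc1cc(C=O)ccc1OCc1cn(CCCOc2ccc3ccc(=O)oc3c2)nn1` is not yet measured. It differs from compound 1 by 4-formyl-2-methoxyphenyl in place of 2-formylphenyl on an oxygen on a saturated carbon. Among the measured compounds shown here, no measured step bears on this change directly: the only measured step, a 2.1-fold lower number from compound 1 to compound 2 (0.32 log units; beyond the scatter), concerns a different part of the molecule and was itself modest. With nothing comparable to go on, the change is expected to leave the number close to that of compound 1, with no step beyond the scatter in either direction. Compound 3 is therefore estimated at 15000 nM in this assay, within a range from 7000 nM to 35000 nM, which corresponds to an expected step of a 1.3-fold lower number from compound 1 to compound 3 (0.10 log units; within the scatter).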

Compound 3, half-maximal inhibitory concentration: 65400 nM
For compound 3 the middle estimate is 4.4-fold (0.64 log units) below the measured one, outside the stated range (above it).
By their numbers in this assay, from the lowest: compound 2; then compound 1; then compound 3.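

In this assay, the exchange on an oxygen on a saturated carbon gives a 3.5-fold higher number from compound 1 to compound 3 (0.54 log units; beyond the scatter), showing that the number can also rise beyond the scatter through a change in this aromatic group. Among the compounds shown here, the only earlier step, a 2.1-fold lower number from compound 1 to compound 2 (0.32 log units; beyond the scatter), ran the other way. The exchange, however, alters two things at once, as the formyl group's place differs and a methoxy group enters, and no measured evidence accounts for the step.

The compounds shown leave open whether the formyl group's place or the methoxy group carries the rise, as neither change is seen alone. They also leave open what a carboxylic acid in place of the formyl group, or a longer chain in place of the methoxy group, would do to the number.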